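Dimethylamino for Methoxy on Compound 3

The compounds below may be only part of what the source reports. "The series", "measured", "known", "first", "only" and "open" are said of these compounds alone.

In a functional assay on HeLa cells (Homo sapiens) for cytotoxicity, read by MTT assay, with a stated time of 24 h (on this read-out higher numbers stand for weaker inhibition and lower numbers for stronger inhibition), compound 3 (`COc1ccc(/C=C(\C#N)C(=O)N/N=C(\C)c2c(O)c3ccc(O)cc3oc2=O)cc1`) gives 7850 nM. That value lies within the scatter of both compound 1 (`C/C(=N\NC(=O)/C(C#N)=C/c1ccc(O)cc1)c1c(O)c2ccc(O)cc2oc1=O`), at 6020 nM, and compound 2 (`COc1ccc(/C=C(\C#N)C(=O)N/N=C(\C)c2c(O)c3ccc(O)cc3oc2=O)cc1OC`), at 13500 nM. Compound 4 (`C/C(=N\NC(=O)/C(C#N)=C/c1ccc(N(C)C)cc1)c1c(O)c2ccc(O)cc2oc1=O`) has dimethylamino in place of methoxy on an aromatic carbon, para to a large group (dimethylamino in place of methoxy on an aromatic carbon). Among the compounds with values here, three measured steps bear on this change. Both a 1.3-fold higher number from compound 1 to compound 3 (0.12 log units; within the scatter) and a 1.7-fold lower number from compound 2 to compound 3 (0.24 log units; within the scatter) stay within the scatter, while a 2.2-fold higher number from compound 1 to compound 2 (0.35 log units; beyond the scatter) is modest. Within the data shown here, no measured compound carries dimethylamino, so the data suggest no direction. The expected change is small, a 1.0-fold lower number from compound 3 to compound 4 (0.02 log units; within the scatter), and nothing beyond the scatter is expected. For compound 4 the estimated value is 7500 nM, with an expected range of 3500 nM to 15000 nM.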

Compound 4, half-maximal inhibitory concentration: 5140 nM
Estimate against measurement, compound 4: 1.5-fold (0.16 log units) above; measured number inside the range.
By their numbers in this assay, from the lowest: compounds 4, 1, 3 and 2 (each within the scatter of the next, the first and the last beyond it).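

With dimethylamino in place of methoxy on an aromatic carbon, para to a large group, this assay shows a step within the scatter (  a 1.5-fold lower number from compound 3 to compound 4 (0.18 log units; within the scatter)). Dimethylamino in place of hydroxy at this carbon also stays within it (a 1.2-fold lower number from compound 1 to compound 4 (0.07 log units; within the scatter)). Only the change from 3,4-dimethoxyphenyl to 4-(dimethylamino)phenyl goes beyond it (a 2.6-fold lower number from compound 2 to compound 4 (0.42 log units; beyond the scatter)), and nothing measured here explains these numbers. Open, on these data alone, is whether a morpholine ring or a carboxylic acid at this carbon would also stay within the scatter.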